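Bromine for Chlorine on a Thiophene Cytotoxicity Series

A few compounds are considered here, and "the series" means these few. Any claim that something is new, unique, unknown or untested is made for them only; others in the source may bear on it.

Compound 1, `Clc1ccsc1C1=NNC(c2ccc(N3CCCCC3)cc2)C1`: 34200 nM in an ADME assay on PBMC cells (Homo sapiens) for cytotoxicity, with a stated time of 5 days; a higher number here means a weaker inhibitor, a lower number a stronger inhibitor
Compound 2, `Clc1ccc(C2=NNC(c3ccc(N4CCCCC4)cc3)C2)s1`: > 100000 nM, a limit of this assay

Compound 2 is the weaker of the two measured compounds in this assay, standing at the limit of > 100000 nM in this assay, at which 1 of the 2 values shown sits, so only a limit and no number is known for it. For the measured compounds named here, the single measured step, an at least 2.9-fold higher number from compound 1 to compound 2 (0.46 log units; beyond the scatter), concerns where the chloro sits on the thiophene, not which halogen it is. Compound 3, `Brc1ccc(C2=NNC(c3ccc(N4CCCCC4)cc3)C2)s1`, differs from compound 2 by bromo in place of chloro on an aromatic carbon. Going by the values given here, no measured step bears on a chlorine-to-bromine exchange, and the measured step does not inform it. Compound 3 is therefore expected to show no step beyond the scatter in this assay, and the estimated change is a step that the limit leaves unreadable from compound 2 to compound 3. Compound 3 is estimated at 120000 nM, with an expected range from 40000 nM to 400000 nM, most likely again reported only as a limit.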

Compound 3, half-maximal inhibitory concentration: 80000 nM
Compound 3: the middle estimate sits 1.5-fold (0.18 log units) above what was measured, within the range that was stated.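

With bromo on the aromatic carbon next to the ring sulfur, compound 3 gives 80000 nM in this assay and so brings a readable number to this position. The exchange of chloro for bromo gives an at least 1.2-fold lower number from compound 2 to compound 3 (0.09 log units; that floor lies within the scatter) and can be sized no further, as one end of it is a limit: the limit of > 100000 nM in this assay, at which 1 of the 3 values shown sits. The change from 3-chlorothiophen-2-yl to 5-bromothiophen-2-yl gives a 2.3-fold higher number from compound 1 to compound 3 (0.37 log units; beyond the scatter) and so puts a number on a difference that the earlier pair could only bound, though here the halogen and its place change together.

The compounds shown leave open how a methyl group, an iodine or an amine on this same carbon would read. They also leave open how much of the step from 3-chlorothiophen-2-yl belongs to the halogen's place alone.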